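Reshaping the Thienyl Group on a Nucleoside Core

The compounds below may be only part of what the source reports. "The series", "measured", "known", "first", "only" and "open" are said of these compounds alone.

Going by the values given here, compound 2 `Cc1csc(-c2ncnc3c2ncn3C2O[C@H](CO)[C@@H](O)[C@H]2O)c1` gives 2900 nM in a functional assay on CCRF-CEM cells (Homo sapiens) for inhibition (on this read-out lower numbers stand for stronger inhibition and higher numbers for weaker inhibition), the lowest of the two numbers so far; its nearest neighbour, compound 1 `Cc1csc(-c2ncnc3c2ncn3C2O[C@H](CO)[C@@H](O)[C@H]2O)n1`, gives 6000 nM. Among the compounds with values here, the single measured step, a 2.1-fold lower number from compound 1 to compound 2 (0.32 log units; beyond the scatter), concerns a different exchange and bears only loosely on the next change. Compound 3 `OC[C@H]1OC(n2cnc3c(-c4ccsc4)ncnc32)[C@H](O)[C@@H]1O` differs from compound 2 by thiophen-3-yl in place of 4-methylthiophen-2-yl on an aromatic carbon. Within the data shown here, no measured step tests the loss of the methyl or the altered point of attachment, so only a small shift in this assay is expected, in either direction. Compound 3 is therefore estimated at 4000 nM, within 1500 nM to 12000 nM, a change of a 1.4-fold higher number from compound 2 to compound 3 (0.14 log units; within the scatter).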

Compound 3, half-maximal inhibitory concentration: 1640 nM
Beside the measured number, compound 3's estimate is 2.4-fold (0.39 log units) above it; low and high end bracket the measured number.
By their numbers in this assay, from the lowest: compounds 3 and 2 (each within the scatter of the next); then compound 1.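

With thiophen-3-yl in place of 4-methylthiophen-2-yl, this assay shows a 1.8-fold lower number from compound 2 to compound 3 (0.25 log units; within the scatter), so this exchange at the position leaves no readable shift. Set against the 4-methyl-1,3-thiazol-2-yl of compound 1, the same group gives a 3.7-fold lower number from compound 1 to compound 3 (0.56 log units; beyond the scatter), a step that does stand beyond the scatter. Nothing available offers an explanation for either step.

Compound 2 and compound 3 differ in both the methyl and the point of attachment, and these two changes remain unseparated. From the compounds shown here alone, how an amine, a carboxylic acid or a phenyl on this aromatic carbon would read in this assay also remains open.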